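Swapping methylsulfonyl for chloro in a cytotoxicity series

The source may report more compounds than this note shows. Statements on the series, on what has been measured and on what is new or still open speak of the compounds shown alone.

For the measured compounds named here, in an ADME assay on MT4 cells (Homo sapiens) for cytotoxicity, read by MTT assay, with a stated time of 5 days (a lower number here means that less compound is tolerated, a higher number that more compound is tolerated), compound 1 `Cc1cc(C)cc(S(=O)(=O)n2c(SCC(=O)Nc3ccccc3S(C)(=O)=O)nc3ccccc32)c1` gives 9310 nM as the only exact number so far. For compound 2 `Cc1cc(C)cc(S(=O)(=O)n2c(OCC(=O)Nc3ccc(S(N)(=O)=O)cc3Cl)nc3ccccc32)c1` the reading is only a limit: > 227000 nM and no exact number. Compound 3 `Cc1cc(C)cc(S(=O)(=O)n2c(SCC(=O)Nc3ccccc3Cl)nc3ccccc32)c1` carries chloro in place of the methylsulfonyl of compound 1 on an aromatic carbon, ortho to a large group (chloro in place of methylsulfonyl on an aromatic carbon). Going by the values given here, no measured pair shows this swap alone. The expected step of a 1.3-fold higher number from compound 1 to compound 3 (0.11 log units; within the scatter) is estimated to stay within the usual scatter of this assay and to have no firm direction. For compound 3 the estimate is 12000 nM and between 3000 nM and 60000 nM is the expected range.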

Compound 3, half-maximal cytotoxic concentration: 107000 nM
Beside the measured number, compound 3's estimate is 8.9-fold (0.95 log units) below it, and the stated range ends below it.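

In this assay, the position on the aromatic carbon ortho to a large group turns out to matter: chloro in place of methylsulfonyl gives an 11-fold higher number from compound 1 to compound 3 (1.06 log units; beyond the scatter), so much more compound is tolerated. Compounds 1 and 2 differ in more than one place, so they could not isolate this single change. Only compound 2 reads as a limit rather than a number: the limit of > 227000 nM in this assay, at which 1 of the 3 values shown sits.

The compounds shown do not reveal why the number moves. On these data alone, whether an amine or a plain hydrogen at this position would give a similar step also remains open.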